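Removing the ring benzyl of compound 2

A few compounds are considered here, and "the series" means these few. Any claim that something is new, unique, unknown or untested is made for them only; others in the source may bear on it.

Compound 2 `O[C@@H]1[C@@H](OCc2ccccc2)[C@H](OCc2ccccc2)[C@@H](COCc2ccccc2)O[C@H]1Cc1ccccc1` stands lowest of the two numbers in hand: in a functional assay on HL-60 cells (Homo sapiens) for antiproliferative activity, read by MTT assay (on this read-out lower numbers stand for stronger inhibition and higher numbers for weaker inhibition), compound 2 gives 8700 nM. Compound 3 `O[C@@H]1[C@@H](O)[C@H](Cc2ccccc2)O[C@H](COCc2ccccc2)[C@H]1OCc1ccccc1` gives 26600 nM, and compound 1 `CC(=O)O[C@@H]1[C@@H](OCc2ccccc2)[C@H](OCc2ccccc2)[C@@H](COCc2ccccc2)O[C@H]1Cc1ccccc1` is reported as "not active" (no number reported), with no number. The step from compound 2 to compound 4 `O[C@H]1CO[C@H](COCc2ccccc2)[C@@H](OCc2ccccc2)[C@@H]1OCc1ccccc1` is hydrogen in place of benzyl on a saturated ring carbon. For the measured compounds named here, the one measured step that bears on it is a 3.1-fold higher number from compound 2 to compound 3 (0.49 log units; beyond the scatter), where a benzyl also gave way to hydrogen, though there on an oxygen rather than on the ring carbon. Loss of a benzyl is therefore expected to raise the number modestly; for compound 4 a step of a 2.5-fold higher number from compound 2 to compound 4 (0.40 log units; beyond the scatter) is estimated. Compound 4 is expected to give about 22000 nM, within 8000 nM to 60000 nM.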

Compound 4, half-maximal inhibitory concentration: "not active" (no number reported)
Nothing numeric was reported for compound 4; no gap can be computed for the estimate.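

For the compounds shown here, compound 4 carries no number in this assay, so no step from compound 2 can be read. No supporting evidence bears on this result. The compounds shown leave open how far loss of the benzyl shifts the read-out.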